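Ethyl to acetyl on the side-chain oxygen of compound 1

The compounds below may be only part of what the source reports. "The series", "measured", "known", "first", "only" and "open" are said of these compounds alone.

Measured in an assay on HEK293 cells for agonist activity at transient receptor potential cation channel subfamily M member 8 (Homo sapiens), read by fluorescence and calcium flux, with a stated time of 5 min; on this read-out lower numbers stand for an effect already at smaller amounts and higher numbers for an effect only at larger amounts of compound:
- compound 1, `C=CCc1cc(OC)c(O[C@H](C)[C@@H](OCC)c2ccc(O)c(OC)c2)c(OC)c1`: 1150 nM
- compound 2, `C=CCc1cc(OC)c(OC(C)C(OCC)c2ccc(O)c(OC)c2)c(OC)c1`: 332 nM
- compound 3, `C=CCc1cc(OC)c(O[C@H](C)[C@H](OCC)c2ccc(O)c(OC)c2)c(OC)c1`: 583 nM

Among these three, compound 1 has the highest number. The gap to compound 3 is a 2.0-fold lower number from compound 1 to compound 3 (0.30 log units; within the scatter), so those two cannot be told apart; the gap to compound 2 is a 3.5-fold lower number from compound 1 to compound 2 (0.54 log units; beyond the scatter). The three measured compounds share all atoms and bonds and differ only in how the two stereocentres are drawn, as shown by the fact that one of compounds 1 and 2 is drawn with a defined configuration and the other without, at the place where they differ, the fact that compounds 1 and 3 differ only in the configuration as drawn and (the fact that one of compounds 2 and 3 is drawn with a defined configuration and the other without, at the place where they differ).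

Compound 4, `C=CCc1cc(OC)c(O[C@H](C)[C@@H](OC(C)=O)c2ccc(O)c(OC)c2)c(OC)c1`, is a different kind of change: acetyl in place of ethyl on an oxygen on a saturated carbon. Going by the values given here, none of the measured steps touches the ethyl group, so they give no guide to what an acetyl in its place will do in this assay , in either direction. Among the compounds with values here, with no comparable step to lean on, compound 4 is expected to stay near compound 1, estimated at 1200 nM (range 300 nM to 5000 nM), which would mean an expected step of a 1.0-fold higher number from compound 1 to compound 4 (0.02 log units; within the scatter), with a wide margin on both sides.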

Compound 4, half-maximal effective concentration: > 10000 nM
Compound 4 was reported as a limit (the forecaster's own chance of this, stated with the estimate: 10%); at least 8.3-fold (0.92 log units) between middle value and limit.
By their numbers in this assay, from the lowest: compounds 2, 3 and 1 (each within the scatter of the next, the first and the last beyond it). At a limit, above all of these: compound 4.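

In this assay the side-chain oxygen of compound 1 proves sensitive to what it carries: acetyl in place of ethyl gives an at least 8.6-fold higher number from compound 1 to compound 4 (0.93 log units; beyond the scatter) and so a larger step than any seen so far between the compounds that differ only in how their stereocentres are drawn. Compound 4 stands at a limit of the assay and not at a number: the limit of > 10000 nM in this assay, at which 1 of the 4 values shown sits. Going by these compounds alone, the earlier compounds showed only what the drawn configuration does, whereas this is the first sign that the group on this oxygen can matter in its own right.

On these data alone, what stays open is whether the carbonyl of acetyl is what counts here or whether other groups on this oxygen would behave the same way. A methyl, a propyl chain or a free hydroxyl in this place could help to separate these, as could acetyl on the configurations of compound 2 and compound 3.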